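The source may report more compounds than this note shows. Statements on the series, on what has been measured and on what is new or still open speak of the compounds shown alone.

Compound 2 `CC(C)(C)C1=NN(c2ccc(Cl)cc2)C(c2ccc(Br)cc2)C1` stands highest of the two numbers gathered so far. In an assay on isolated protein for inhibition of protein kinase C zeta type (Homo sapiens), with a stated time of 4 min, tested at 62.5 uM (on this read-out higher numbers stand for more inhibition at the one concentration tested (going by the name of the read-out) and lower numbers for less inhibition), compound 2 gives 39%, while compound 1 `CC(C)(C)C1=NN(c2ccc(Cl)cc2)C(c2ccc(F)cc2)C1` gives 0%. Going by the values given here, the single measured step between them is a number 39 percentage points higher from compound 1 to compound 2 (beyond the scatter), a large step that exceeds the scatter.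

Compound 3 `CC(C)(C)C1=NN(c2ccc(Cl)cc2)C(c2cccc(O)c2)C1` differs from compound 2 in one place: 3-hydroxyphenyl in place of 4-bromophenyl on a saturated ring carbon. Among the compounds with values here, no measured step speaks to this change directly. Within the data shown here, the one step available, a number 39 percentage points higher from compound 1 to compound 2 (beyond the scatter), concerns only the exchange of one halogen for another on an aromatic carbon of the same ring and says nothing about a hydroxyl group. What it does show is that the number in this assay rose sharply when bromine replaced fluorine, and that the bromine is now lost altogether. On that slender basis a fall is expected, though its size is very uncertain. Compound 3 is therefore expected to give about 15%, with a range from 0% to 45%. The step this estimate implies, a number 24 percentage points lower from compound 2 to compound 3 (beyond the scatter), is expected to run downward.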

Compound 3, a percentage reported as inhibition, at one concentration (the size of the read-out at that concentration, not a potency): 95.6%
For compound 3 the middle estimate is 80.6 percentage points below the measured one, outside the stated range (above it).
By their numbers in this assay, from the lowest: compound 1; then compound 2; then compound 3.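

At the saturated ring carbon next to the ring nitrogen, the aryl group can do far more in this assay than the halogen exchange alone revealed: 3-hydroxyphenyl in place of 4-bromophenyl gives a number 56.6 percentage points higher from compound 2 to compound 3 (beyond the scatter), and in place of 4-fluorophenyl it gives a number 95.6 percentage points higher from compound 1 to compound 3 (beyond the scatter). Compound 1 and compound 2 varied only the halogen on a 4-substituted phenyl group, whereas compound 3 shows that the highest number of the three comes with a hydroxyl group, carried at a different place on the phenyl ring and with no halogen on it. No measurement at hand accounts for this rise, so the reason for it remains unknown.

The compounds shown do not separate the effect of the hydroxyl group from the effect of its place on the phenyl ring, a question that 4-hydroxyphenyl and 3-bromophenyl would address directly. Also open, on these data alone, is whether the hydroxyl itself matters, which 3-methoxyphenyl or 3-aminophenyl would test, and whether the tert-butyl and 4-chlorophenyl groups contribute to the number reached by compound 3.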